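A few compounds are considered here, and "the series" means these few. Any claim that something is new, unique, unknown or untested is made for them only; others in the source may bear on it.

Measured so far:
- compound 1, `CC[C@H](C)[C@H](N)CN(C(=O)[C@@H]1C[C@H]1c1ccccc1Cl)c1ccc(-c2ccccc2)cc1`: > 25000 nM
- compound 2, `CC[C@H](C)[C@H](N)CN(C(=O)[C@@H]1C[C@H]1c1ccccc1)c1ccc(-c2ccc(C(C)(C)C)cc2)cc1`: 750 nM

Of the compounds shown here, two have been measured in a functional assay for agonist activity at G protein-coupled receptor 88 (Homo sapiens), read by HTRF and cAMP accumulation; a lower number here means that less compound is needed, a higher number that more compound is needed for the effect. For compound 1 the result is a limit of the assay, > 25000 nM, and not a number. Among the compounds with values here, compound 2 gives 750 nM in this assay, which is the only number among the two values. The other value, that of compound 1, sits at the limit of > 25000 nM in this assay, at which 1 of the 2 values shown sits. Within the data shown here, no step between measured compounds that differ in one place is available, so compound 1 and compound 2 can only be read side by side.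

Compound 3, `CC[C@H](C)[C@H](N)CN(C(=O)[C@@H]1C[C@H]1c1ccccc1)c1ccc(-c2ccc(CO)cc2)cc1`, is not yet measured. Its difference from compound 2 is hydroxymethyl in place of tert-butyl on an aromatic carbon. A clear loss in potency in this assay is expected, as an 11-fold higher number from compound 2 to compound 3 (1.03 log units; beyond the scatter). Compound 3 is estimated at 8000 nM, with a range from 2000 nM to 25000 nM, and there is a real chance that this assay returns only a limit for it.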

Compound 3, half-maximal effective concentration: 1100 nM
Compound 3: middle estimate off by 7.3-fold (0.86 log units), on the high side; the measured number lies below the stated range.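

Read in this assay, placing hydroxymethyl in place of tert-butyl on this aromatic carbon gives a 1.5-fold higher number from compound 2 to compound 3 (0.17 log units; within the scatter). The two compounds cannot be told apart here, so at this position, para to a large group, tert-butyl is not needed for a value of this order, and a group with fewer heavy atoms that adds a hydrogen-bond donor and acceptor serves equally well. Nothing in the data shown accounts for this equivalence.

Compound 1 gives > 25000 nM, a limit of the assay and not a number, and it differs from the other two compounds in more than one place, so it says nothing about this position. On these data alone, whether an amine, a carboxylic acid or a longer chain ending in a hydroxyl would hold up equally at this carbon in this assay remains open.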